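The compounds below may be only part of what the source reports. "The series", "measured", "known", "first", "only" and "open" are said of these compounds alone.

Series notes. In a functional assay on H266 cells (Homo sapiens) for cytotoxicity, read by resazurin assay, with a stated time of 72 h (a lower number here means a stronger inhibitor, a higher number a weaker inhibitor), compound 1 `COc1cc(/C=C/C(=O)OC(C)CCOc2no[n+]([O-])c2S(=O)(=O)c2ccccc2)ccc1O` gives 430 nM. Compound 2 `O=C(/C=C/c1ccc(O)c(O)c1)OCc1c(-c2ccccc2)no[n+]1[O-]` gives 14200 nM in this assay, the highest of the two numbers shown, with compound 1 the nearest to it and a lower value, beyond the scatter. Compound 3 `COc1cc(/C=C/C(=O)OC(C)C)ccc1O` returns only a limit of the assay, > 50000 nM, not a number. That limit is recorded on its own (the limit of > 50000 nM in this assay, at which 1 of the 3 values shown sits).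

The step followed here runs from compound 2 to compound 4 `COc1cc(/C=C/C(=O)OCc2c(-c3ccccc3)no[n+]2[O-])ccc1O`, which has not yet been measured in this assay. The change is methyl in place of hydrogen on an oxygen on an aromatic ring, so the 3,4-dihydroxyphenyl of compound 2 becomes the 4-hydroxy-3-methoxyphenyl that compound 1 and compound 3 carry, while the rest of compound 2 is kept. Within the data shown here, no measured pair differs by this change alone, so the size of the step is open. Compound 1 and compound 3 share the 4-hydroxy-3-methoxyphenyl yet sit far apart in this assay, which says the phenyl substitution is not what separates them. A step of small size, in either direction and probably not beyond the scatter, is expected in this assay. Compound 4 is estimated at 15000 nM, between 5000 nM and 45000 nM. The expected step from compound 2 to compound 4 is thus a 1.1-fold higher number from compound 2 to compound 4 (0.02 log units; within the scatter).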

Compound 4, half-maximal inhibitory concentration: 13400 nM
For compound 4 the middle estimate is 1.1-fold (0.05 log units) above the measured one, and the stated range covers the measured number.
By their numbers in this assay, from the lowest: compound 1; then compounds 4 and 2 (each within the scatter of the next). At a limit, above all of these: compound 3.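

In this assay, among these compounds, the first measured pair for this change gives a 1.1-fold lower number from compound 2 to compound 4 (0.03 log units; within the scatter) and so shows that hydroxy to methoxy, at this oxygen on an aromatic ring, leaves the number where it was. With the rest of compound 2 kept, the free hydroxy given up in compound 4 is not required for the level of cytotoxicity read here, and the 3,4-dihydroxyphenyl and the 4-hydroxy-3-methoxyphenyl can be treated as interchangeable on this core, though that rests on this single pair. The values shown give no cause for this flat step.

From the compounds shown here alone, the pair speaks for one core only, so whether hydroxy to methoxy is equally silent on the core of compound 1 remains open. Also open, going by these compounds, is how much this oxygen tolerates beyond a methyl: an ethoxy or a benzyloxy in place of the methoxy, or an amine or a carboxylic acid in place of the hydroxy, would show whether the flat response extends to larger or charged groups at this position.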